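The source may report more compounds than this note shows. Statements on the series, on what has been measured and on what is new or still open speak of the compounds shown alone.

Measured so far:
- compound 1, `COc1ccccc1N1CCN(CCCNC(=O)NN(Cc2ccccc2F)c2ccc(Cl)cc2)CC1`, gives 2.6 nM in an assay on CHO cells for displacement of a labelled ligand from D(4) dopamine receptor (Homo sapiens), read by radioligand binding; a higher number here means a weaker inhibitor, a lower number a stronger inhibitor
- compound 2, `COc1ccc(N(Cc2ccc(F)cc2)NC(=O)NCCCN2CCN(c3ccccc3OC)CC2)cc1`, gives 2.9 nM in this assay
- compound 3, `O=C(NCCCN1CCN(c2ccc(Cl)cc2)CC1)NN(Cc1ccccc1)c1ccccc1`, gives 9.7 nM in this assay

Compound 3 stands with the highest number of the three, which here means the weakest binding. Its nearest neighbour is compound 2, whose number is lower by a step beyond the scatter, and compound 1 sits lower still, also beyond the scatter. Compound 3 is therefore clearly weaker than both, though all three remain in the low nanomolar region.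

Compound 4, `O=C(NCCCN1CCN(c2ncccn2)CC1)NN(Cc1ccccc1)c1ccccc1`, has not yet been measured. It differs from compound 3 in one place: pyrimidin-2-yl in place of 4-chlorophenyl on an amine nitrogen in a ring. Among the compounds with values here, no measured pair shows this particular swap, so its effect is unknown. Within the data shown here, with nothing to lean on but the single value of compound 3, the expected step from compound 3 to compound 4 is a 2.1-fold higher number from compound 3 to compound 4 (0.31 log units; beyond the scatter), a modest weakening that may or may not reach beyond the scatter. Compound 4 is thus estimated at 20 nM, with a range from 5 nM to 80 nM.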

Compound 4, inhibition constant: 18 nM
The estimate for compound 4 lay 1.1-fold (0.05 log units) above the measured number, and the stated range covers the measured number.
By their numbers in this assay, from the lowest: compounds 1 and 2 (each within the scatter of the next); then compounds 3 and 4 (each within the scatter of the next).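

In this assay, within the data shown here, this is the first comparison in the set where only one place differs, and replacing 4-chlorophenyl with pyrimidin-2-yl on the ring amine nitrogen gives a step within the usual scatter (a 1.9-fold higher number from compound 3 to compound 4 (0.27 log units; within the scatter)). Compound 3 and compound 4 therefore cannot be told apart here, even though the entering ring has two nitrogens and two hydrogen-bond acceptors, and the leaving group has a chlorine and no acceptors. No measurement shown gives a reason for this result.

From the compounds shown here alone, this is a single pair on one shared core, so it remains open whether the swap would give a similar step with the other groups carried by compound 1 and compound 2. Also open, going by these compounds, is how a pyridin-2-yl or an acetyl group would behave on the same nitrogen.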